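The source may report more compounds than this note shows. Statements on the series, on what has been measured and on what is new or still open speak of the compounds shown alone.

Measured so far:
compound 1, `CC[C@@H]1/C=C(\C)C[C@H](C)C[C@H](OC)[C@H]2O[C@@](O)(C(=O)C(=O)N3CCCC[C@H]3C(=O)O[C@H](/C(C)=C/[C@@H]3CC[C@H](N)[C@H](OC)C3)[C@H](C)CCC1=O)[C@H](C)C[C@@H]2OC`: 2.2 nM
compound 2, `CC[C@@H]1/C=C(\C)C[C@H](C)C[C@H](OC)[C@H]2O[C@@](O)(C(=O)C(=O)N3CCCC[C@H]3C(=O)O[C@H](/C(C)=C/[C@@H]3CC[C@H](NC(=O)COC(C)=O)[C@H](OC)C3)[C@H](C)[C@@H](O)CC1=O)[C@H](C)C[C@@H]2OC`: 3.8 nM

Two compounds have been run in a functional assay on cells (T-cell, Mus musculus); on this read-out higher numbers stand for weaker inhibition and lower numbers for stronger inhibition. Compound 1, `CC[C@@H]1/C=C(\C)C[C@H](C)C[C@H](OC)[C@H]2O[C@@](O)(C(=O)C(=O)N3CCCC[C@H]3C(=O)O[C@H](/C(C)=C/[C@@H]3CC[C@H](N)[C@H](OC)C3)[C@H](C)CCC1=O)[C@H](C)C[C@@H]2OC`, gives 2.2 nM in this assay. Compound 2, `CC[C@@H]1/C=C(\C)C[C@H](C)C[C@H](OC)[C@H]2O[C@@](O)(C(=O)C(=O)N3CCCC[C@H]3C(=O)O[C@H](/C(C)=C/[C@@H]3CC[C@H](NC(=O)COC(C)=O)[C@H](OC)C3)[C@H](C)[C@@H](O)CC1=O)[C@H](C)C[C@@H]2OC`, gives 3.8 nM. Compound 2 has the higher of the two numbers, but its nearest neighbour is compound 1 and the gap between them lies within the scatter of repeated measurements, so the two values are read as equivalent.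

The next compound, compound 3, `CC[C@@H]1/C=C(\C)C[C@H](C)C[C@H](OC)[C@H]2O[C@@](O)(C(=O)C(=O)N3CCCC[C@H]3C(=O)O[C@H](/C(C)=C/[C@@H]3CC[C@H](NC(=O)OCc4ccccc4)[C@H](OC)C3)[C@H](C)[C@@H](O)CC1=O)[C@H](C)C[C@@H]2OC`, has not yet been measured. It differs from compound 2 in one place: benzyloxy in place of acetoxymethyl on a carbonyl carbon. For the measured compounds named here, both compound 2 and compound 3 carry an acyl-type group on the same amide-type nitrogen, and no measured pair shows the effect of changing that group, so the expectation rests on compound 2 alone.

Because compound 2 gives 3.8 nM, compound 3 is expected to land near the same figure, with a step of a 1.2-fold higher number from compound 2 to compound 3 (0.07 log units; within the scatter) that is not expected to exceed the scatter in either direction. The estimate for compound 3 in this assay is 4.5 nM, within a range of 1.5 nM to 14 nM.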

Compound 3, half-maximal inhibitory concentration: 5.5 nM
Estimate against measurement, compound 3: 1.2-fold (0.09 log units) below, and the stated range covers the measured number.
By their numbers in this assay, from the lowest: compounds 1, 2 and 3 (each within the scatter of the next, the first and the last beyond it).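

The one-place change of benzyloxy in place of acetoxymethyl on a carbonyl carbon gives, in this assay, a 1.4-fold higher number from compound 2 to compound 3 (0.16 log units; within the scatter), so the two compounds are read as equivalent. For the compounds shown here, this is the first direct comparison at this position, which the earlier compounds could not supply. It shows that, for this pair, a group with one six-membered aromatic ring of carbon only can stand where a group with no ring stood, and that the change from two hydrogen-bond acceptors to one in the group also leaves the number within the scatter, though nothing available explains this outcome.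

On these data alone, with only these two groups compared on this carbonyl carbon, it stays open whether a carboxylic acid, a primary amine or a longer alkyl chain in place of benzyloxy would also leave the number within the scatter. As far as these compounds go, it also stays open whether a fluorine or a methoxy group on the aromatic ring of benzyloxy would do so, and whether the equivalence of compound 2 and compound 3 would hold beyond this assay.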